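This account rests on a few compounds, and the source may have more. Where it says the series, first, only, none or still open, it means among the compounds named here.

Measured so far:
compound 1 `COC(=O)C1=C(C)N=C(C)/C(=C(/O)OC)C1c1cccc(N/C(=N/CCNC2CCN(c3ccccc3)CC2)NC#N)c1`: 10 nM in an assay on SK-N-MC cells for inhibition of Neuropeptide Y receptor type 1 (Homo sapiens); on this read-out higher numbers stand for weaker inhibition and lower numbers for stronger inhibition
compound 2 `COC(=O)C1=C(C)N=C(C)/C(=C(/O)OC)C1c1cccc(N/C(=N/CCNC2CCN(c3ccccc3C(F)(F)F)CC2)NC#N)c1`: 14 nM in this assay

Going by the values given here, compound 2 gives the higher of the two numbers, but its only neighbour is compound 1 and the step of a 1.4-fold higher number from compound 1 to compound 2 (0.15 log units; within the scatter) lies within the scatter, so the two compounds are indistinguishable here. Compound 3 `COC(=O)C1=C(C)N=C(C)/C(=C(/O)OC)C1c1cccc(N/C(=N/CCNC2CCN(c3ccccc3O)CC2)NC#N)c1` differs from compound 2 by hydroxy in place of trifluoromethyl on an aromatic carbon. Among the compounds with values here, the one step that bears on this place, a 1.4-fold higher number from compound 1 to compound 2 (0.15 log units; within the scatter), shows that exchanging the group on this aromatic carbon moved the number little. For compound 3 the expected step is therefore a 1.2-fold lower number from compound 2 to compound 3 (0.07 log units; within the scatter), nothing beyond the scatter. The estimate for compound 3 in this assay is 12 nM, within 5 nM to 30 nM.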

Compound 3, half-maximal inhibitory concentration: 5 nM
Compound 3: the middle estimate sits 2.4-fold (0.38 log units) above what was measured; measured number inside the range.
By their numbers in this assay, from the lowest: compounds 3, 1 and 2 (each within the scatter of the next, the first and the last beyond it).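

In this assay this position now gives a step beyond the scatter: hydroxy in place of trifluoromethyl gives a 2.8-fold lower number from compound 2 to compound 3 (0.45 log units; beyond the scatter) and is modest in size, whereas the earlier pair could not be told apart. Hydroxy in place of hydrogen gives a 2.0-fold lower number from compound 1 to compound 3 (0.30 log units; within the scatter) and so does not separate compound 3 from compound 1; only the two substituted compounds are distinct.

Still open, as far as these compounds go, is whether this step belongs to hydroxy specifically, which methoxy or an amine on this aromatic carbon would help to settle. No evidence at hand bears on the reason for the step.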